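Trifluoromethyl in Place of Ethoxy: Expected Antiproliferative Read-Out

The source may hold more compounds than are shown below. What is called first, only, known or untested is meant among the compounds shown, and "the series" means these compounds.

Of the compounds shown here, three have been measured in a functional assay on Hep 3B2 cells (Homo sapiens) for antiproliferative activity, read by MTT assay, with a stated time of 24 h, tested at 0.41 ug/mL; a higher number here means a stronger effect of the compound at the concentration tested, a lower number a weaker effect. Compound 1 `Cc1c(C(=O)Nc2c(F)cc(-c3cccc(F)c3)cc2F)nc2ccc(C(F)(F)F)cc2c1O` gives 9.38%, compound 2 `CCc1ccc2nc(C(=O)Nc3c(F)cc(-c4cccc(F)c4)cc3F)c(C)c(C(=O)O)c2c1` gives 1.68%, and compound 3 `CCOc1ccc2nc(C(=O)Nc3c(F)cc(-c4cccc(F)c4)cc3F)c(C)c(C(=O)O)c2c1` gives 5.34%. Compound 3 stands second of the three numbers, with compound 2 nearest and compound 1 furthest, both within the scatter. Among the measured compounds shown here, the only step between compounds differing in one place, a number 3.7 percentage points higher from compound 2 to compound 3 (within the scatter), lay within the scatter. Compound 4 `Cc1c(C(=O)Nc2c(F)cc(-c3cccc(F)c3)cc2F)nc2ccc(C(F)(F)F)cc2c1C(=O)O` differs from compound 3 by trifluoromethyl in place of ethoxy on an aromatic carbon. For the measured compounds named here, no measured step covers this exchange, and the one step that exists concerns a different change. With all three numbers within the scatter of one another, compound 4 is expected to stay in the same low region, the estimated step being a number 0.7 percentage points higher from compound 3 to compound 4 (within the scatter). Compound 4 is therefore estimated at 6%, between 0% and 15%.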

Compound 4, a percentage reported as inhibition, at one concentration (the size of the read-out at that concentration, not a potency): 6.42%
For compound 4 the middle estimate is 0.4 percentage points below the measured one; low and high end bracket the measured number.
By their numbers in this assay, from the lowest: compounds 2, 3, 4 and 1 (each within the scatter of the next).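

In this assay trifluoromethyl in place of ethoxy gives a number 1.1 percentage points higher from compound 3 to compound 4 (within the scatter) and trifluoromethyl in place of ethyl gives a number 4.7 percentage points higher from compound 2 to compound 4 (within the scatter) on this aromatic carbon, so ethyl, ethoxy and trifluoromethyl all read alike here. Carboxy in place of hydroxy gives a number 3 percentage points lower from compound 1 to compound 4 (within the scatter) and so also leaves the read-out unresolved from the scatter. No evidence at hand explains these numbers. On these data alone, whether an amine, a nitrile or a longer chain at this position would give a read-out beyond the scatter remains open. So does any difference among these compounds at other concentrations.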